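The compounds below may be only part of what the source reports. "The series", "measured", "known", "first", "only" and "open" are said of these compounds alone.

Measured so far in a functional assay on MCF7 cells (Homo sapiens) for antiproliferative activity, read by CCK-8 assay, with a stated time of 72 h; on this read-out higher numbers stand for weaker inhibition of growth and lower numbers for stronger inhibition of growth
- compound 1 `CC[C@@H]1C(=O)N(C)c2cnc(-n3ccc4ccccc43)nc2N1C1CCCC1` gives 17200 nM
- compound 2 `CC[C@@H]1C(=O)N(C)c2cnc(-n3ccc4cc(F)ccc43)nc2N1C1CCCC1` is reported as "not active" (no number reported)
- compound 3 `CCCCNC(=O)c1ccc2c(ccn2-c2ncc3c(n2)N(C2CCCC2)[C@H](CC)C(=O)N3C)c1` gives 634 nM

Compound 3 at 634 nM holds the lower of the two numbers available, and compound 2 adds no number to compare. Compound 4 `CC[C@@H]1C(=O)N(C)c2cnc(-n3ccc4cc(C(=O)NCC(C)C)ccc43)nc2N1C1CCCC1` has the same atoms as compound 3, joined differently: isopropyl in place of propyl on a saturated chain carbon bound to an amide-type nitrogen is the whole change, which reads as butylcarbamoyl to isobutylcarbamoyl. Among the measured compounds shown here, the one measured step bearing on this is a 27-fold lower number from compound 1 to compound 3 (1.43 log units; beyond the scatter) and it is large, beyond the scatter, for butylcarbamoyl in place of hydrogen on an aromatic carbon. For the measured compounds named here, no measured step alters the chain itself, so that size does not carry over to a swap that keeps the butylcarbamoyl atoms. A step within the scatter is expected in this assay with no firm direction. The expected step is a 1.3-fold higher number from compound 3 to compound 4 (0.10 log units; within the scatter) as an estimate only. In this assay the estimate for compound 4 is 800 nM with an expected range from 300 nM to 2500 nM on repeated measurement.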

Compound 4, concentration for 50% growth inhibition: 953 nM
Estimate against measurement, compound 4: 1.2-fold (0.08 log units) below; measured number inside the range.
By their numbers in this assay, from the lowest: compounds 3 and 4 (each within the scatter of the next); then compound 1.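

In this assay, isobutylcarbamoyl in place of butylcarbamoyl gives a 1.5-fold higher number from compound 3 to compound 4 (0.18 log units; within the scatter) on this read-out, so the two chains cannot be told apart here. The large step at this aromatic carbon now stands for two chains, an 18-fold lower number from compound 1 to compound 4 (1.26 log units; beyond the scatter) alongside a 27-fold lower number from compound 1 to compound 3 (1.43 log units; beyond the scatter) for the same place, so it does not depend on the straight butyl form alone. Nothing measured here explains either the size of these steps or the lack of separation between the two chains.

Still open, on these data alone, is how far the chain can change at this place: a shorter ethyl, a longer hexyl, or a chain ending in an amine or a carboxylic acid could each behave differently. Also open, as far as these compounds go, is whether the amide hydrogen matters, which a dimethylamide at the same carbon would test.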